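This account rests on a few compounds, and the source may have more. Where it says the series, first, only, none or still open, it means among the compounds named here.

Measured so far:
Compound 1, `COC[C@H](NC1CCN(CCCc2c[nH]c3ccc(-n4cnnc4)cc23)CC1)c1ccccc1`, gives 3 nM in an assay on CHO cells for binding affinity to 5-hydroxytryptamine receptor 1D (Homo sapiens); on this read-out higher numbers stand for weaker inhibition and lower numbers for stronger inhibition.
Compound 2, `C[C@H](NC1CCN(CCCc2c[nH]c3ccc(-n4cnnc4)cc23)CC1)c1ccccc1`, gives 0.6 nM in this assay.

Compound 2 holds the lowest number of the two in this assay; its nearest neighbour is compound 1, and the gap between them is a 5.0-fold lower number from compound 1 to compound 2 (0.70 log units; beyond the scatter), a modest step that lies beyond the scatter.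

Compound 3, `CC(CO)(NC1CCN(CCCc2c[nH]c3ccc(-n4cnnc4)cc23)CC1)c1ccccc1`, has not yet been measured in this assay. It differs from compound 2 in one place: 1-(hydroxymethyl)-1-phenylethyl in place of 1-phenylethyl on an amine nitrogen. Among the compounds with values here, the one measured step that bears on this change is the one from compound 1 to compound 2, where hydrogen in place of methoxy on the saturated chain carbon gave a 5.0-fold lower number from compound 1 to compound 2 (0.70 log units; beyond the scatter). Compound 3 goes the other way, putting a group with one hydrogen-bond donor and one hydrogen-bond acceptor back onto the amine substituent, so a step of similar size toward a higher number in this assay is expected, estimated as a 5.0-fold higher number from compound 2 to compound 3 (0.70 log units; beyond the scatter). On that basis compound 3 is expected to give about 3 nM in this assay, with a plausible range from 1 nM to 10 nM.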

Compound 3, half-maximal inhibitory concentration: 5.2 nM
Estimate against measurement, compound 3: 1.7-fold (0.24 log units) below, within the range that was stated.
By their numbers in this assay, from the lowest: compound 2; then compounds 1 and 3 (each within the scatter of the next).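

On the amine nitrogen, 1-(hydroxymethyl)-1-phenylethyl in place of 1-phenylethyl gives an 8.7-fold higher number from compound 2 to compound 3 (0.94 log units; beyond the scatter) in this assay, which shows that this position also responds to a change at the carbon carrying the phenyl ring, not only to the methoxy-bearing chain of compound 1. Within the data shown here, the step from 2-methoxy-1-phenylethyl to 1-(hydroxymethyl)-1-phenylethyl is a 1.7-fold higher number from compound 1 to compound 3 (0.24 log units; within the scatter), so these two oxygen-bearing substituents cannot be told apart here, and among the three compounds only compound 2, whose substituent has no oxygen, stands apart from the others, with no compound going against this. Nothing measured here explains either step.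

The change to compound 3 adds both a methyl and a hydroxyl-bearing carbon to the substituent and removes the defined stereocentre, so the compounds shown do not separate the contributions of these differences. As far as these compounds go, it remains open how 1-methyl-1-phenylethyl, which carries a plain methyl in place of the hydroxymethyl, or an aminomethyl or carboxylic acid group at that carbon would read in this assay.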